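The compounds below may be only part of what the source reports. "The series", "measured", "known", "first", "only" and "open" are said of these compounds alone.

Compound 1 `COc1ccc(Cn2c(=O)nc(NCCNC(=N)N)n(Cc3ccc(C)cc3)c2=O)cc1` gives 0.0045 nM in a functional assay on the whole organism (strain C57Bl/6) for inhibition, with Mus musculus as the target, with a stated time of 180 min, at 48 degrees C; a higher number here means that more compound is needed for the effect, a lower number that less compound is needed.
Compound 2 `Cc1ccc(Cn2c(NCCNC(=N)N)nc(=O)n(Cc3ccc(C(F)(F)F)cc3)c2=O)cc1` gives 0.000033 nM in this assay.
Compound 3 `COc1ccc(Cn2c(NCCNC(=N)N)nc(=O)n(Cc3ccc(Cl)cc3)c2=O)cc1` gives 0.004 nM in this assay.

Among these three numbers compound 3 stands second highest. Its nearest neighbour is compound 1, whose number lies within the scatter of it, while compound 2 sits far lower. Compound 4 `COc1ccc(Cn2c(NCCNC(=N)N)nc(=O)n(Cc3ccc(F)cc3)c2=O)cc1` differs from compound 3 by fluoro in place of chloro on an aromatic carbon. Among the compounds with values here, no measured step covers this change. Within the data shown here, the only step known, a 140-fold lower number from compound 1 to compound 2 (2.13 log units; beyond the scatter), was large, but it concerns trifluoromethyl in place of methoxy, a different group, and says nothing about a halogen exchange. With no guidance from the data, the exchange is expected to give no step beyond the scatter. Compound 4 is therefore estimated at 0.006 nM in this assay, with a range of 0.0015 nM to 0.025 nM, meaning an expected step of a 1.5-fold higher number from compound 3 to compound 4 (0.18 log units; within the scatter).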

Compound 4, half-maximal effective concentration: 0.00031 nM
For compound 4 the middle estimate is 19-fold (1.29 log units) above the measured one; the whole stated range lies above it.
By their numbers in this assay, from the lowest: compound 2; then compound 4; then compounds 3 and 1 (each within the scatter of the next).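

In this assay, changing 4-chlorobenzyl to 4-fluorobenzyl gives a 13-fold lower number from compound 3 to compound 4 (1.11 log units; beyond the scatter) and so moves the number well beyond the scatter. Within the data shown here, until now, the only large step was trifluoromethyl in place of methoxy, whereas this one shows that exchanging one halogen atom for another on this aromatic carbon is enough. No evidence given here accounts for the size of this step. Open, from the compounds shown here alone, is how a bromo group or an amine at this place would compare with fluoro. Also open, going by these compounds, is whether the exchange gives a similar step when the 4-methoxybenzyl group elsewhere on the core is replaced.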